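Swapping the halogenated ring in a pyridine-amide series

This account rests on a few compounds, and the source may have more. Where it says the series, first, only, none or still open, it means among the compounds named here.

Compound 1 `O=C(Nc1ccc(I)cc1)c1cncc(N2CC3CC(C2)N3)c1` is tested in an assay on membranes from Cerebral cortex for displacement of a labelled ligand from Neuronal acetylcholine receptor; alpha4/beta2 (Rattus norvegicus) (a lower number here means a stronger inhibitor, a higher number a weaker inhibitor), where compound 1 gives 0.366 nM. Going by the values given here, this is the lowest of the three numbers measured so far. Compound 2 `COc1cccc(NC(=O)c2cncc(N3CC4CC(C3)N4)c2)c1` gives 0.56 nM, and compound 3 `O=C(Nc1ccccc1)c1cncc(N2CC3CC(C2)N3)c1` gives 1.1 nM. The step of a 1.5-fold higher number from compound 1 to compound 2 (0.18 log units; within the scatter) stays inside the usual scatter, whereas a 3.0-fold higher number from compound 1 to compound 3 (0.48 log units; beyond the scatter) is a modest but real loss; a 2.0-fold higher number from compound 2 to compound 3 (0.29 log units; within the scatter) again lies within the scatter.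

Compound 4 `O=C(Nc1cccc(Cl)c1)c1cncc(N2CC3CC(C2)N3)c1` has not yet been measured. Compared with compound 1 it carries 3-chlorophenyl in place of 4-iodophenyl on an amide-type nitrogen. Among the compounds with values here, two measured steps bear on this change: removing the iodo group altogether, as from compound 1 to compound 3, costs a modest amount, while replacing the 4-iodophenyl by a 3-methoxyphenyl, as from compound 1 to compound 2, costs almost nothing. A 3-chlorophenyl keeps a halogen on the ring but moves to the pattern of compound 2, so a small upward step, at most about as large as a 1.5-fold higher number from compound 1 to compound 2 (0.18 log units; within the scatter) and smaller than a 3.0-fold higher number from compound 1 to compound 3 (0.48 log units; beyond the scatter), is expected. Compound 4 is therefore estimated at 0.55 nM, within 0.22 nM to 1.4 nM, meaning an expected step of a 1.5-fold higher number from compound 1 to compound 4 (0.18 log units; within the scatter).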

Compound 4, inhibition constant: 0.042 nM
The estimate for compound 4 lay 13-fold (1.12 log units) above the measured number; measured number below the stated range.
By their numbers in this assay, from the lowest: compound 4; then compounds 1, 2 and 3 (each within the scatter of the next, the first and the last beyond it).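

The aromatic group on the amide-type nitrogen proves far more sensitive in this assay than compounds 1, 2 and 3 suggested, since 3-chlorophenyl in place of 4-iodophenyl gives an 8.7-fold lower number from compound 1 to compound 4 (0.94 log units; beyond the scatter) and places compound 4 lowest of the four. On the same ring, chloro in place of hydrogen gives a 26-fold lower number from compound 3 to compound 4 (1.42 log units; beyond the scatter) and chloro in place of methoxy gives a 13-fold lower number from compound 2 to compound 4 (1.12 log units; beyond the scatter) in this series, so the identity of the group on that aromatic carbon sets the number, and not merely the presence of a group there. Nothing shown offers a measured explanation for these steps.

Compound 4 differs from compound 1 in both the halogen and its place on the ring, and with neither a 4-chlorophenyl nor a 3-iodophenyl among the compounds shown, the two changes cannot be separated. From the compounds shown here alone, it also remains open whether fluoro, bromo, methyl or an amine on that same aromatic carbon would match chloro, and whether a second chloro on the ring would add to the step or reverse it.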